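Swapping a Chlorine Position on a Benzyl Thioether

The compounds below may be only part of what the source reports. "The series", "measured", "known", "first", "only" and "open" are said of these compounds alone.

Compound 1, `CC1=C(C(=O)Nc2ccc(Br)cc2)C(c2ccc(Cl)cc2Cl)N=C(SCc2ccccc2Cl)N1`, gives 16% in a functional assay on the whole organism (artery, strain albino) with Rattus norvegicus as the target, with a stated time of 120 min, at a dose of 10 mg/kg by the oral route; on this read-out lower numbers stand for less inhibition and higher numbers for more inhibition at the one dose given (going by the name of the read-out).
Compound 2, `CC1=C(C(=O)Nc2ccc(Br)cc2)C(c2ccc(Cl)cc2Cl)N=C(SCc2cccc(Cl)c2)N1`, gives 8.8%.
Compound 3, `CC1=C(C(=O)Nc2ccc([N+](=O)[O-])cc2)C(c2cccc([N+](=O)[O-])c2)N=C(SCc2ccccc2Cl)N1`, gives 7.7%.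

Compound 1 and compound 2 share one core and differ in a single place: 3-chlorophenyl in place of 2-chlorophenyl on a saturated chain carbon bound to a sulfur. In this assay that change gave a number 7.2 percentage points lower from compound 1 to compound 2 (within the scatter). Compound 3 has a different core; how the core of compound 3 differs from the core of compound 1 is not broken down here. Compound 4, `CC1=C(C(=O)Nc2ccc([N+](=O)[O-])cc2)C(c2cccc([N+](=O)[O-])c2)N=C(SCc2cccc(Cl)c2)N1`, is not yet measured and differs from compound 3 by the same change: 3-chlorophenyl in place of 2-chlorophenyl on a saturated chain carbon bound to a sulfur. Because the earlier step of a number 7.2 percentage points lower from compound 1 to compound 2 (within the scatter) stayed within the scatter, a similarly small step is expected here too: a number 2.7 percentage points lower from compound 3 to compound 4 (within the scatter). Compound 4 is therefore estimated at 5% in this assay, with a range from 0% to 15%.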

Compound 4, a percentage reported as inhibition, in the whole organism at one dose (the size of the read-out at that dose, not a potency): 12.4%
Compound 4: middle estimate off by 7.4 percentage points, on the low side; low and high end bracket the measured number.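

Replacing 2-chlorobenzyl with 3-chlorobenzyl gave a number 4.7 percentage points higher from compound 3 to compound 4 (within the scatter) in this assay, so on this second core the change again stayed within the usual scatter. Set beside each other, the two steps do not differ by more than that scatter allows: the same change on two cores in this assay, a number 7.2 percentage points lower (within the scatter) from compound 1 to compound 2 and a number 4.7 percentage points higher (within the scatter) from compound 3 to compound 4, 11.9 percentage points apart, within the scatter of two such steps. This gives no sign that the core alters the effect of the change, but it does not prove the effect is the same on both cores, and a small real effect could remain hidden in the scatter.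

Going by these compounds, what stays open is whether a different group in place of the chlorine, such as an amine or a carboxylic acid, would give a step beyond the scatter. A longer chain between the sulfur and the ring is an open question too.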